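The compounds below may be only part of what the source reports. "The series", "measured", "known", "first", "only" and "open" are said of these compounds alone.

Compound 1: `C/C(=C\c1nn(CCC(C)C)c(=O)c(C2=NS(=O)(=O)c3cc(NS(C)(=O)=O)ccc3N2)c1O)C(F)(F)F` — 0.167 h
Compound 2: `CC(C)CCc1nn(CCC(C)C)c(=O)c(C2=NS(=O)(=O)c3cc(NS(C)(=O)=O)ccc3N2)c1O` — 0.167 h
Compound 3: `COC(C)(C)CCn1nc(-c2cccs2)c(O)c(C2=NS(=O)(=O)c3cc(NS(C)(=O)=O)ccc3N2)c1=O` — > 1 h

These three compounds share one core and were tested in an in vitro ADME assay on microsomes from liver (Homo sapiens) for metabolic stability, tested at 5 uM; on this read-out higher numbers stand for a longer-lived compound and lower numbers for a shorter-lived compound. Compound 1 and compound 2 sit at the same short half-life, and the step of no change at the digits printed from compound 1 to compound 2 (within the scatter) shows no change beyond the scatter when an isopentyl replaces a 2-(trifluoromethyl)prop-1-en-1-yl on an aromatic carbon. Compound 3 stands apart: its value is a limit of this assay, not a number, so its half-life is only known to be beyond that limit, as the limit of > 1 h in this assay, at which 1 of the 3 values shown sits, records.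

Compound 4, `CS(=O)(=O)Nc1ccc2c(c1)S(=O)(=O)N=C(c1c(O)c(-c3cccs3)nn(Cc3ccccc3)c1=O)N2`, differs from compound 3 in one place: phenyl in place of 2-methoxy-2-methylpropyl on a saturated chain carbon bound to an aromatic nitrogen. Going by the values given here, the only measured step concerns a different part of the core, the group on an aromatic carbon, and it was flat within the scatter; no measured step tells how a change on the chain bound to the aromatic nitrogen moves this assay. Since compound 3 gives only a limit, even the starting point is uncertain. The expectation is therefore a wide one, with a step of an at least 1.4-fold lower number from compound 3 to compound 4 (0.15 log units; that floor lies within the scatter) reflecting mostly the loss of the known long-lived reading. Compound 4 is estimated at 0.7 h, within 0.2 h to 2 h.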

Compound 4, half-life: > 1 h
Compound 4: no number, only a limit (the forecaster's own chance of this, stated with the estimate: 40%); middle value at least 1.4-fold (0.15 log units) from the limit.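

Compound 3 and compound 4 each give only a limit in this assay, not a number, so no step can be read between them: the limit of > 1 h in this assay, at which 2 of the 4 values shown sit.

The compounds shown leave open how far past that limit either half-life lies, and whether phenyl in place of 2-methoxy-2-methylpropyl lengthens it, shortens it or leaves it unchanged.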